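Removing One Chloro From Compound 3

The source may report more compounds than this note shows. Statements on the series, on what has been measured and on what is new or still open speak of the compounds shown alone.

Compound 3 `Cc1nc(-c2cccc(F)c2)c(C(=O)N2CCN(c3cc(Cl)cc(Cl)c3)CC2)o1` is measured in a functional assay on HL-60 cells (Homo sapiens) for inhibition, read by MTT assay, with a stated time of 72 h (on this read-out higher numbers stand for weaker inhibition and lower numbers for stronger inhibition), at 41.7 nM. Among the three numbers known, that places compound 3 second highest: compound 1 `Cc1nc(-c2ccccc2F)c(C(=O)N2CCN(c3cccc(Cl)c3)CC2)o1` gives 39.4 nM, within the scatter of compound 3, while compound 2 `CCc1nc(-c2cccc(F)c2)c(C(=O)N2CCN(c3cccc(Cl)c3)CC2)o1` gives 317 nM, beyond the scatter. Compound 4 `Cc1nc(-c2cccc(F)c2)c(C(=O)N2CCN(c3cccc(Cl)c3)CC2)o1` is not yet measured. From compound 3 to compound 4 the change is hydrogen in place of chloro on an aromatic carbon, on an aromatic carbon of a six-membered aromatic ring of carbon only. Among the compounds with values here, no measured pair shows this step, so its size can only be expected. Compound 1, which also carries a single chloro on that ring, gives 39.4 nM in this assay. On that basis the step from compound 3 to compound 4 is expected to be none beyond the scatter, a 1.2-fold higher number from compound 3 to compound 4 (0.08 log units; within the scatter). Compound 4 is therefore estimated at 50 nM, between 20 nM and 150 nM.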

Compound 4, half-maximal inhibitory concentration: 33.7 nM
The estimate for compound 4 lay 1.5-fold (0.17 log units) above the measured number; the measured number falls inside the stated range.
By their numbers in this assay, from the lowest: compounds 4, 1 and 3 (each within the scatter of the next); then compound 2.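

In this assay the change from 3,5-dichlorophenyl to 3-chlorophenyl gives a 1.2-fold lower number from compound 3 to compound 4 (0.09 log units; within the scatter) and so shows that this chloro can leave without a shift beyond the scatter. Having 3-fluorophenyl in place of 2-fluorophenyl gives a 1.2-fold lower number from compound 1 to compound 4 (0.07 log units; within the scatter) while hydrogen in place of methyl on the saturated chain carbon gives a 9.4-fold lower number from compound 2 to compound 4 (0.97 log units; beyond the scatter) and is the only one of these steps beyond the scatter. Nothing at hand explains these steps.

Open, from the compounds shown here alone, is what happens if the remaining chloro gives way to hydrogen, a methoxy or a nitrile. Also open, going by these compounds, is how a longer chain, such as propyl, would read.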